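The source may hold more compounds than are shown below. What is called first, only, known or untested is meant among the compounds shown, and "the series" means these compounds.

The study concerns a small set of compounds sharing one core, tested in a functional assay on RAW264.7 cells (Mus musculus) for cytotoxicity, read by MTT assay, with a stated time of 48 h; a lower number here means a stronger inhibitor, a higher number a weaker inhibitor. Compound 1, `Cc1ccc(C2=Nn3c(Cc4ccc(S(C)(=O)=O)cc4)nnc3SC2)cc1`, carries a 4-methylphenyl group on that core. In this assay compound 1 gives > 100000 nM, which is a limit of the assay and not a number. Compound 2, `CS(=O)(=O)c1ccc(Cc2nnc3n2N=C(c2cc4ccccc4c(=O)o2)CS3)cc1`, is the second measured member of the set. In this assay compound 2 likewise gives only a limit, > 100000 nM. Among the measured compounds shown here, both measured values thus sit at the same point, as the limit of > 100000 nM in this assay, at which 2 of the 2 values shown sit, records, so no step between measured compounds can be drawn, and where compound 1 stands is told only by that limit.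

Compound 3, `CS(=O)(=O)c1ccc(Cc2nnc3n2N=C(c2cc(Cl)sc2Cl)CS3)cc1`, is not yet measured. It differs from compound 1 in one place: 2,5-dichlorothiophen-3-yl in place of 4-methylphenyl on a carbon with a double bond to nitrogen. For the measured compounds named here, with no measured step to lean on, the expected step of a number no higher from compound 1 to compound 3 (the limit leaves the size open) is none beyond the usual scatter of the assay. Compound 3 is therefore expected to give about 100000 nM in this assay, within a range of 50000 nM to 200000 nM, and most probably to be reported again only as a limit.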

Compound 3, half-maximal inhibitory concentration: > 100000 nM
Compound 3 was reported as a limit (the forecaster's own chance of this, stated with the estimate: 85%); the middle value sits exactly at the limit.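

Compound 3 and compound 1 are both reported in this assay only as limits, so no step between them can be read, and swapping 4-methylphenyl for 2,5-dichlorothiophen-3-yl yields no size: the limit of > 100000 nM in this assay, at which 3 of the 3 values shown sit.

The compounds shown leave open whether any change on the shared core would give a readable value in this assay.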